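The source may report more compounds than this note shows. Statements on the series, on what has been measured and on what is new or still open speak of the compounds shown alone.

Measured so far in this series:
compound 1 `CN(C)CCCn1cc[n+](C)c1/C=N/O` is reported in a physicochemical assay for lipophilicity (on this read-out lower numbers stand for lower lipophilicity and higher numbers for higher lipophilicity), only as a limit of the assay, < -3.
compound 2 `CN(CCCn1cc[n+](C)c1/C=N/O)S(=O)(=O)C(F)(F)F` gives in this assay -1.37.
compound 3 `C[n+]1ccn(CCCN(Cc2ccccc2)S(=O)(=O)C(F)(F)F)c1/C=N/O` gives in this assay 0.06.

Compound 2 holds the lowest of the two numbers that are real values; its nearest neighbour is compound 3, with a number 1.43 log units higher from compound 2 to compound 3 (beyond the scatter). Compound 1 sits at the limit of < -3 in this assay, at which 1 of the 3 values shown sits, so the step from it, a number at least 1.63 log units higher from compound 1 to compound 2 (beyond the scatter), is known only as a lower bound.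

Compound 4 `CN(CCCn1cc[n+](C)c1/C=N/O)S(=O)(=O)c1ccccc1` differs from compound 2 by phenyl in place of trifluoromethyl on a sulfonyl sulfur. Within the data shown here, no measured step swaps these two groups at this position. The two measured steps that bear on it are the large upward step from compound 2 to compound 3, where a phenyl-bearing group enters on the sulfonamide nitrogen, and the bounded step from compound 1 to compound 2, where the trifluoromethylsulfonyl group itself enters. Both show that changes around this sulfonamide move this read-out by more than the scatter. Here a trifluoromethyl group leaves as the phenyl enters. An upward step in this assay is therefore expected for compound 4, giving a number 0.77 log units higher from compound 2 to compound 4 (beyond the scatter). The estimate for compound 4 is -0.6, in the range -1.3 to 0.1.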

Compound 4, distribution coefficient: -1.59
The estimate for compound 4 lay 0.99 log units above the measured number, outside the stated range (below it).
By their numbers in this assay, from the lowest: compounds 4 and 2 (each within the scatter of the next); then compound 3. At a limit, below all of these: compound 1.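

In this assay, phenyl in place of trifluoromethyl on a sulfonyl sulfur reads as a number 0.22 log units lower from compound 2 to compound 4 (within the scatter), so this read-out does not separate the two groups at this position. Phenyl therefore has no single outcome in this series: entering on a saturated chain carbon bound to a sulfonamide nitrogen, it gave a number 1.43 log units higher from compound 2 to compound 3 (beyond the scatter). Nothing measured in the series accounts for this difference between the two steps.

On these data alone, whether a methyl group or a pyridine ring on the sulfonyl sulfur would also stay within the scatter of compound 2 remains open. Also open, as far as these compounds go, is whether the phenyl-bearing group on the sulfonamide nitrogen of compound 3 would give a step of similar size with phenyl rather than trifluoromethyl on the sulfonyl sulfur.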